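This account rests on a few compounds, and the source may have more. Where it says the series, first, only, none or still open, it means among the compounds named here.

Of the compounds shown here, three sharing one core have been tested in a functional assay on BGC-823 cells (Homo sapiens) for cytotoxicity, read by MTT assay, with a stated time of 48 h; a lower number here means a stronger inhibitor, a higher number a weaker inhibitor. Compound 1, `O=C(CSc1nnc(-c2ccncc2)o1)N/N=C/c1ccc(Cl)cc1`, gives 20500 nM. Compound 2, `O=C(CSc1nnc(-c2ccncc2)o1)N/N=C/c1cccc(F)c1`, gives 27500 nM, and compound 3, `O=C(CSc1nnc(-c2ccncc2)o1)N/N=C/c1ccccc1O`, gives 6160 nM. Among these three numbers compound 1 stands second highest: the step of a 1.3-fold higher number from compound 1 to compound 2 (0.13 log units; within the scatter) lies within the scatter, so nothing separates compounds 1 and 2, while the step of a 3.3-fold lower number from compound 1 to compound 3 (0.52 log units; beyond the scatter) and the step of a 4.5-fold lower number from compound 2 to compound 3 (0.65 log units; beyond the scatter) are both modest but real, marking compound 3 apart from the other two.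

Compound 4, `O=C(CSc1nnc(-c2ccncc2)o1)N/N=C/c1ccc(Cl)cc1Cl`, differs from compound 1 by chloro in place of hydrogen on an aromatic carbon. Within the data shown here, none of the measured steps tests this same kind of change: the steps from compound 1 to compound 2 and from compound 2 to compound 3 swap one ring substituent for another, and the step from compound 1 to compound 3 does the same. Among the measured compounds shown here, no step adds a second chloro while keeping the 4-chlorophenyl. For the measured compounds named here, the only guide is that moving a single halogen, as in a 1.3-fold higher number from compound 1 to compound 2 (0.13 log units; within the scatter), left the number unchanged within the scatter. On that basis a step from compound 1 to compound 4 of about a 1.4-fold lower number from compound 1 to compound 4 (0.14 log units; within the scatter) is expected, most likely within the scatter. Compound 4 is therefore estimated at 15000 nM, with a range from 5000 nM to 45000 nM.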

Compound 4, half-maximal inhibitory concentration: 35600 nM
For compound 4 the middle estimate is 2.4-fold (0.38 log units) below the measured one; measured number inside the range.
By their numbers in this assay, from the lowest: compound 3; then compounds 1, 2 and 4 (each within the scatter of the next).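

Adding a chloro to the 4-chlorophenyl ring of compound 1, on the carbon ortho to a large group, gives a 1.7-fold higher number from compound 1 to compound 4 (0.24 log units; within the scatter) in this assay, so this position accepts a second chlorine without a change that can be told from the scatter, and a 1.3-fold higher number from compound 2 to compound 4 (0.11 log units; within the scatter) shows no separation from the 3-fluorophenyl compound either. By contrast, a 5.8-fold higher number from compound 3 to compound 4 (0.76 log units; beyond the scatter) sets compound 3 apart from compound 4, as it already stood apart from compounds 1 and 2, although this swap alters two places on the ring at once and so does not isolate the effect of either one. No measurement is available that would explain these numbers.

On these data alone, it remains open whether the lower number of compound 3 belongs specifically to the hydroxyl on its ring or would also appear with another group there, such as a methoxy or an amine. A single chloro in that same place, as in 2-chlorophenyl, would separate the contribution of this position from that of the chloro in 2,4-dichlorophenyl.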